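Swapping the pyridyl of compound 1 for 4-chlorophenyl

The source may hold more compounds than are shown below. What is called first, only, known or untested is meant among the compounds shown, and "the series" means these compounds.

Measured compounds:
compound 1, `COc1cc(-c2nc(C(c3ccc(F)cc3)c3ccc(F)cc3)sc2CC(=O)O)ccn1`, 29 nM
compound 2, `COc1ccc(OC)c(-c2nc(C(c3ccccc3)c3ccccc3)sc2CC(=O)O)c1`, > 105 nM
compound 3, `O=C(O)Cc1sc(C(c2ccccc2)c2ccccn2)nc1-c1ccc(Cl)cc1`, 810 nM

Three compounds sharing one core were tested in an in vitro assay on HEK385-7 cells for displacement of a labelled ligand from prostaglandin D2 receptor 2 (Homo sapiens); a lower number here means a stronger inhibitor, a higher number a weaker inhibitor. Compound 1 gives 29 nM, the lowest of the two numbers reported. Compound 3 gives 810 nM, a number well beyond the scatter from that of compound 1. For compound 2 only a limit of the assay is reported, > 105 nM, and not a number; (the limit of > 105 nM in this assay, at which 1 of the 3 values shown sits).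

Compound 4, `O=C(O)Cc1sc(C(c2ccc(F)cc2)c2ccc(F)cc2)nc1-c1ccc(Cl)cc1`, has not been measured in this assay. It differs from compound 1 in one place: 4-chlorophenyl in place of 2-methoxypyridin-4-yl on an aromatic carbon. The 4-chlorophenyl group also appears in compound 3, which carries a different diaryl group and gives the weaker of the two numbers; how much of that rests on the 4-chlorophenyl cannot be read from these three compounds.

Within the data shown here, no measured pair isolates this change. The step from compound 1 to compound 4 in this assay is expected to be small, toward a higher number, and near the edge of the scatter, as a 2.1-fold higher number from compound 1 to compound 4 (0.32 log units; beyond the scatter). Compound 4 is accordingly estimated at 60 nM, with a likely range from 15 nM to 300 nM.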

Compound 4, half-maximal inhibitory concentration: 9.7 nM
Beside the measured number, compound 4's estimate is 6.2-fold (0.79 log units) above it; measured number outside the range, below it.
By their numbers in this assay, from the lowest: compound 4; then compound 1; then compound 3.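

In this assay the exchange on the aromatic carbon next to the ring nitrogen gives a 3.0-fold lower number from compound 1 to compound 4 (0.48 log units; beyond the scatter) and shows that this position does not depend on the 2-methoxypyridin-4-yl group: a ring of carbon only, with no hydrogen-bond acceptors, serves at least as well here. The earlier compounds shown here left the role of 4-chlorophenyl unclear, as it appeared only in compound 3. Compound 4 gives 9.7 nM while compound 3 gives 810 nM with the same 4-chlorophenyl, so that group does not by itself bring a weak number, and these two compounds differ in their diaryl group.

From the compounds shown here alone, whether the lower number follows from the chlorine or from the loss of the ring nitrogen and methoxy group stays open, and a 4-bromophenyl or 4-methoxyphenyl group at this position would be needed to separate the two. Nothing in the data shown bears on what lies behind this step.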